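This account rests on a few compounds, and the source may have more. Where it says the series, first, only, none or still open, it means among the compounds named here.

The measured compounds and their values:

compound 1, `Cc1ccc(NC2=CC(=O)c3nc4n(c3C2=O)[C@H]2OC[C@@H](O)[C@H]2OC4)cc1` — 1660 nM
compound 2, `COc1ccc(NC2=CC(=O)c3c(nc4n3[C@H]3OC[C@@H](O)[C@H]3OC4)C2=O)cc1` — 4470 nM
compound 3, `O=C1C=C(NC2CCCC2)C(=O)c2c1nc1n2[C@H]2OC[C@@H](O)[C@H]2OC1` — > 16000 nM

In a functional assay on MCF7 cells (Homo sapiens) for inhibition, read by sulforhodamine B assay (a higher number here means a weaker inhibitor, a lower number a stronger inhibitor), compound 2 gives 4470 nM, the higher of the two numbers reported, with compound 1 lower by a gap beyond the scatter. Compound 3 sits at a limit of this assay, > 16000 nM, and no number is known for it. The limit is set out as the limit of > 16000 nM in this assay, at which 1 of the 3 values shown sits.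

Compound 4, `O=C1C(NC2CCCCC2)=CC(=O)c2c1nc1n2[C@H]2OC[C@@H](O)[C@H]2OC1`, has not yet been measured in this assay. It differs from compound 2 in one place: cyclohexyl in place of 4-methoxyphenyl on an amine nitrogen.

Among the compounds with values here, one measured step bears on this change. Replacing 4-methylphenyl with cyclopentyl on the amine nitrogen gave an at least 9.6-fold higher number from compound 1 to compound 3 (0.98 log units; beyond the scatter). The change from compound 2 to compound 4 is of the same kind, an aromatic six-membered ring on the amine nitrogen giving way to a saturated carbon ring, so a rise of comparable size is expected, in the direction of a weaker inhibitor. Since compound 2 already starts higher than compound 1, the expectation is that compound 4 will most likely also land beyond the limit of this assay. The expected step from compound 2 to compound 4 is a 7.8-fold higher number from compound 2 to compound 4 (0.89 log units; beyond the scatter). Compound 4 is therefore estimated at 35000 nM, with a range from 12000 nM to 120000 nM.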

Compound 4, half-maximal inhibitory concentration: > 16000 nM
Compound 4: no number, only a limit (the forecaster's own chance of this, stated with the estimate: 70%); the middle value lies beyond the limit too.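

In this assay, cyclohexyl in place of 4-methoxyphenyl on the amine nitrogen gave an at least 3.5-fold higher number from compound 2 to compound 4 (0.55 log units; beyond the scatter), so the rise first seen with cyclopentyl in place of 4-methylphenyl now recurs with a second aromatic group leaving and a second saturated ring entering. From the compounds shown here alone, compound 3 and compound 4, the two compounds with a saturated carbon ring on this nitrogen, both stand at a limit and not at a number: the limit of > 16000 nM in this assay, at which 2 of the 4 values shown sit. The full size of each step therefore remains unknown, and cyclopentyl and cyclohexyl cannot be ranked against each other.

Going by these compounds, it remains open whether a benzyl group, a pyridine ring or an open chain such as n-butyl on this nitrogen would give a number rather than a limit, which would show how far the aromatic ring itself matters. Also open, on these data alone, is how groups other than 4-methylphenyl and 4-methoxyphenyl would read in this assay, for example unsubstituted phenyl, 4-chlorophenyl or 4-(dimethylamino)phenyl.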